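A dimethylamino end on a propyl chain

A few compounds are considered here, and "the series" means these few. Any claim that something is new, unique, unknown or untested is made for them only; others in the source may bear on it.

In a functional assay (trachea) with Cavia porcellus as the target (a lower number here means that less compound is needed, a higher number that more compound is needed for the effect), compound 1 (`CCCn1c(=O)n(CCC#N)c(=O)c2[nH]cnc21`) gives 1700 nM while compound 2 (`CCCn1cnc2c1c(=O)n(C)c(=O)n2CCC`) gives 5000 nM as the higher of the two numbers, a gap beyond the usual scatter. Compound 3 (`CCCn1c(=O)n(C)c(=O)c2c1ncn2CCN(C)C`) differs from compound 2 in one place (dimethylamino in place of methyl on a saturated chain carbon, two bonds along the chain from an aromatic nitrogen): dimethylamino in place of methyl on a saturated chain carbon, two bonds along the chain from an aromatic nitrogen. For the measured compounds named here, no measured pair shows this change, so only a loose expectation is possible: a moderate step towards a higher number in this assay for compound 3. The estimate means a 3.0-fold higher number from compound 2 to compound 3 (0.48 log units; beyond the scatter) as the expected step. For compound 3 the estimated value is 15000 nM (expected range 4000 nM to 60000 nM).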

Compound 3, half-maximal effective concentration: > 100000 nM
Compound 3: a limit, no number (the forecaster's own chance of this, stated with the estimate: 15%); middle value at least 6.6-fold (0.82 log units) away from the limit.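

In this assay, this position on the saturated chain carbon proves highly sensitive to the change from methyl to dimethylamino, with an at least 20-fold higher number from compound 2 to compound 3 (1.30 log units; beyond the scatter). The earlier compounds shown here gave no direct view of this change or of how much it could matter here. For compound 3, the reading is a limit and not a number: the limit of > 100000 nM in this assay, at which 1 of the 3 values shown sits.

As far as these compounds go, whether a plain amino group or a hydroxyl group at the same place would also raise the number remains open. So does whether a longer chain carrying the dimethylamino end would behave the same way.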